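A few compounds are considered here, and "the series" means these few. Any claim that something is new, unique, unknown or untested is made for them only; others in the source may bear on it.

Of the compounds shown here, three built on one shared core have so far been measured in a functional assay on NCI-H1975 cells (Homo sapiens) for inhibition, read by MTT assay, with a stated time of 72 h; on this read-out higher numbers stand for weaker inhibition and lower numbers for stronger inhibition. Compound 1 `C=CC(=O)Nc1cccc(NC(=O)CSc2nc(Nc3ccccc3)c3ccccc3n2)c1` gives 8120 nM in this assay. Compound 2 `C=CC(=O)Nc1cccc(NC(=O)CSc2nc(Nc3ccccc3F)c3ccccc3n2)c1`, which carries fluoro in place of hydrogen on an aromatic carbon, gives 6580 nM, and compound 3 `C=CC(=O)Nc1cccc(NC(=O)CSc2nc(Nc3ccccc3Cl)c3ccccc3n2)c1`, which carries chloro in place of that hydrogen, gives 10000 nM. Compound 3 shows the highest of the three numbers, yet the steps of a 1.2-fold higher number from compound 1 to compound 3 (0.09 log units; within the scatter) and a 1.5-fold higher number from compound 2 to compound 3 (0.18 log units; within the scatter) both lie within the scatter, so no order among the three compounds can be claimed from these values.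

Compound 4 `C=CC(=O)Nc1cccc(NC(=O)CSc2nc(Nc3ccccc3Br)c3ccccc3n2)c1` has not yet been measured. It differs from compound 3 in one place: bromo in place of chloro on an aromatic carbon. The measured steps that bear on such an exchange at this aromatic carbon are a 1.2-fold lower number from compound 1 to compound 2 (0.09 log units; within the scatter), a 1.2-fold higher number from compound 1 to compound 3 (0.09 log units; within the scatter) and a 1.5-fold higher number from compound 2 to compound 3 (0.18 log units; within the scatter), every one of them within the scatter. On this basis the change from compound 3 to compound 4 is expected to produce no step beyond the scatter in this assay, the expected step being no change at the digits printed from compound 3 to compound 4 (within the scatter). The estimate for compound 4 in this assay is accordingly 10000 nM, with an expected range from 5000 nM to 20000 nM.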

Compound 4, half-maximal inhibitory concentration: 19300 nM
The estimate for compound 4 lay 1.9-fold (0.29 log units) below the measured number, within the range that was stated.
By their numbers in this assay, from the lowest: compounds 2, 1, 3 and 4 (each within the scatter of the next, the first and the last beyond it).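

In this assay, within the data shown here, the exchanges among hydrogen, fluoro and chloro at this aromatic carbon, ortho to a large group, had all stayed within the scatter, whereas bromo gives the first steps beyond it, with a 2.4-fold higher number from compound 1 to compound 4 (0.38 log units; beyond the scatter) on replacing hydrogen and a 2.9-fold higher number from compound 2 to compound 4 (0.47 log units; beyond the scatter) on replacing fluoro. The exchange of chloro for bromo itself, a 1.9-fold higher number from compound 3 to compound 4 (0.29 log units; within the scatter) and so within the scatter, does not separate these two halogens, which leaves bromo set apart from hydrogen and fluoro but not from chloro. No measurement that could account for these steps accompanies the values.

On these data alone, all four compounds carry either hydrogen or a single halogen at this carbon, so it remains open whether a methyl, a methoxy or an amine there would stay with hydrogen and fluoro or go with bromo. Also open, as far as these compounds go, is whether a change away from this carbon, such as a carboxylic acid or a longer chain on the shared core, would move the numbers further than these halogens do.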